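N-aryl variation on the triazole of the enone series

A few compounds are considered here, and "the series" means these few. Any claim that something is new, unique, unknown or untested is made for them only; others in the source may bear on it.

The series keeps one core and varies only the aryl group on the triazole nitrogen. Compound 1 `COc1cc(/C=C/C(C)=O)ccc1OCc1cn(-c2c(F)cccc2F)nn1` gives 24200 nM in a functional assay on PC-3 cells (Homo sapiens) for antiproliferative activity, read by MTT assay, with a stated time of 48 h; a lower number here means a stronger inhibitor, a higher number a weaker inhibitor. Compound 2 `COc1cccc(-n2cc(COc3ccc(/C=C/C(C)=O)cc3OC)nn2)c1` gives 31600 nM; the pair shows a 1.3-fold higher number from compound 1 to compound 2 (0.12 log units; within the scatter). Compound 3 `COc1cc(/C=C/C(C)=O)ccc1OCc1cn(-c2ccccc2OC)nn1` gives 2050 nM and stands lowest of the three numbers, with a 12-fold lower number from compound 1 to compound 3 (1.07 log units; beyond the scatter) and a 15-fold lower number from compound 2 to compound 3 (1.19 log units; beyond the scatter). Among the measured compounds shown here, the two large steps both end at the 2-methoxyphenyl, so that group is tied to the only strong number in the set.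

Compound 4 `COc1cc(/C=C/C(C)=O)ccc1OCc1cn(-c2ccc(C)cc2)nn1` differs from compound 3 in one place: 4-methylphenyl in place of 2-methoxyphenyl on an aromatic nitrogen. The change removes the group carrying the only acceptor seen to lower the number. For the measured compounds named here, no measured step has a 4-methylphenyl on this nitrogen, so the direction can be read only from the two aryls already measured without an ortho methoxy, both of which sit far higher than compound 3. On that basis compound 4 is expected to move back toward the range of compound 1 and compound 2, a step of about a 7.3-fold higher number from compound 3 to compound 4 (0.86 log units; beyond the scatter) in this assay.

Compound 4 is therefore estimated at 15000 nM, with a range from 4000 nM to 50000 nM.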

Compound 4, half-maximal inhibitory concentration: 58100 nM
Compound 4: middle estimate off by 3.9-fold (0.59 log units), on the low side; measured number above the stated range.
By their numbers in this assay, from the lowest: compound 3; then compounds 1, 2 and 4 (each within the scatter of the next, the first and the last beyond it).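

In this assay, the exchange of 2-methoxyphenyl for 4-methylphenyl on the aromatic nitrogen gives a 28-fold higher number from compound 3 to compound 4 (1.45 log units; beyond the scatter), so a third aryl group without the 2-methoxy arrangement also stands far above compound 3, and no listed compound goes against this. The new number also falls close to the earlier weak pair, with a 1.8-fold higher number from compound 2 to compound 4 (0.26 log units; within the scatter) and a 2.4-fold higher number from compound 1 to compound 4 (0.38 log units; beyond the scatter); the first comparison shows that 3-methoxyphenyl, which keeps the methoxy group, cannot be told apart from 4-methylphenyl, which has none, so the presence of a methoxy group alone does not go with the low number. No measurement bears on why the step from 2-methoxyphenyl is so large.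

Still open, on these data alone, is whether the low number of compound 3 follows the oxygen itself or any group at that place on the phenyl ring: 2-methylphenyl, 2-hydroxyphenyl and 2-aminophenyl on the same nitrogen would separate these readings. Also open, as far as these compounds go, is whether a longer chain on that oxygen, as in 2-ethoxyphenyl, keeps the number of compound 3.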